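Shortening the side chain from compound 3 to compound 4

A few compounds are considered here, and "the series" means these few. Any claim that something is new, unique, unknown or untested is made for them only; others in the source may bear on it.

Compound 1 `N=C(S)CCn1nc(-c2cccs2)ccc1=O`; in a functional assay on the whole organism (stomach) with Rattus norvegicus as the target (on this read-out higher numbers stand for an effect only at larger amounts of compound and lower numbers for an effect already at smaller amounts), compound 1 gives 100 mg/kg.
Compound 2 `Cc1ccc(=O)n(CCCCCCC(=N)S)n1`; in this assay compound 2 gives > 100 mg/kg, which is a limit of the assay and not a number.
Compound 3 `N=C(S)CCCCCCn1nc(-c2ccccc2)ccc1=O`; in this assay compound 3 gives > 100 mg/kg, again a limit of the assay and not a number.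

Compound 3 therefore stands at the edge of what was measured, with only a limit and no number. For the measured compounds named here, the one step between measured neighbours, a step that the two limits leave unreadable from compound 2 to compound 3, is unreadable, both of its ends sitting at the limit of > 100 mg/kg in this assay, at which 2 of the 3 values shown sit. Going by the values given here, compound 1 is the only member of the series with a number, and no step between compound 1 and compound 3 is available; the two values show merely that compound 1 sits at the value where the other two give a limit.

Compound 4 `N=C(S)CCCCn1nc(-c2ccccc2)ccc1=O` differs from compound 3 by a group of 3 heavy atoms (1 carbon, 1 nitrogen, 1 sulfur; no ring) in place of a group of 5 heavy atoms (3 carbon, 1 nitrogen, 1 sulfur; no ring), on a saturated chain carbon, four bonds along the chain from an aromatic nitrogen. None of the measured steps bears directly on this change, and the one step shown is unreadable. No step beyond the scatter in this assay is therefore expected; a limit is the most likely outcome again. Compound 4 is estimated at 100 mg/kg, between 50 mg/kg and 300 mg/kg, which means an expected step of a number no higher from compound 3 to compound 4 (the limit leaves the size open).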

Compound 4, dose for half-maximal effect: > 100 mg/kg
Compound 4 was reported as a limit; the forecaster's own chance of this, stated with the estimate: 60%; the middle value sits exactly at the limit.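

In this assay compound 4 gives > 100 mg/kg, a limit of the assay and not a number. Compound 3 also sits at a limit, so no step can be read between compound 3 and compound 4: the limit of > 100 mg/kg in this assay, at which 3 of the 4 values shown sit.

The compounds shown leave open whether the shorter side chain of compound 4 changes the effect in this assay at all.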